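A few compounds are considered here, and "the series" means these few. Any claim that something is new, unique, unknown or untested is made for them only; others in the source may bear on it.

In an ADME assay on L02 cells (Homo sapiens) for cytotoxicity, read by MTT assay, with a stated time of 72 h (on this read-out lower numbers stand for stronger inhibition and higher numbers for weaker inhibition), compound 1 `COc1cc(/C=C2\CNC/C(=C\c3cc(OC)c(OC)c(OC)c3)C2=O)cc(OC)c1OC` gives 7600 nM. Compound 2 `COc1cc(/C=C2\CN(C(=O)CCC(=O)O)C/C(=C\c3cc(OC)c(OC)c(OC)c3)C2=O)cc(OC)c1OC` reaches only a limit of the assay, > 60000 nM. Compound 3 `COc1cc(/C=C2\CN(C(=O)C(C)C)C/C(=C\c3cc(OC)c(OC)c(OC)c3)C2=O)cc(OC)c1OC` gives 12200 nM, within the scatter of compound 1. Compound 4 `COc1cc(/C=C2\CN(C(=O)c3ccccc3F)C/C(=C\c3cc(OC)c(OC)c(OC)c3)C2=O)cc(OC)c1OC` differs from compound 3 at one place: 2-fluorophenyl in place of isopropyl on a carbonyl carbon. The closest guide is a 1.6-fold higher number from compound 1 to compound 3 (0.21 log units; within the scatter), on adding isopropylcarbonyl to the ring nitrogen. The larger steps, an at least 7.8-fold higher number from compound 1 to compound 2 (0.89 log units; beyond the scatter) and an at least 4.9-fold lower number from compound 2 to compound 3 (0.69 log units; beyond the scatter), both involve the 2-carboxyethyl group, which compound 4 lacks. The expected step in this assay is therefore a 1.1-fold lower number from compound 3 to compound 4 (0.04 log units; within the scatter), none beyond the scatter. Compound 4 is estimated at 11000 nM, within a range of 4000 nM to 30000 nM.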

Compound 4, half-maximal inhibitory concentration: 4400 nM
The estimate for compound 4 lay 2.5-fold (0.40 log units) above the measured number; the range from low to high includes it.
By their numbers in this assay, from the lowest: compounds 4, 1 and 3 (each within the scatter of the next, the first and the last beyond it). At a limit, above all of these: compound 2.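

On the carbonyl carbon, the group present can move the number in this assay: a 2.8-fold lower number from compound 3 to compound 4 (0.44 log units; beyond the scatter), a change beyond the scatter that involves no 2-carboxyethyl group. Set against the hydrogen of compound 1, however, the new group stays close, with a 1.7-fold lower number from compound 1 to compound 4 (0.24 log units; within the scatter). The widest gap, an at least 13-fold lower number from compound 2 to compound 4 (1.13 log units; beyond the scatter), starts from a limit and not a number: the limit of > 60000 nM in this assay, at which 1 of the 4 values shown sits.

The compounds shown leave open what a plain phenyl, a pyridine or a longer alkyl chain on that carbonyl carbon would give. They also leave open whether the fluorine of the 2-fluorophenyl group plays any part in the step.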